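The source may report more compounds than this note shows. Statements on the series, on what has been measured and on what is new or still open speak of the compounds shown alone.

Two compounds of the series carry numbers in an assay for inhibition of 15-hydroxyprostaglandin dehydrogenase [NAD(+)] (Homo sapiens), read by fluorescence, with a stated time of 15 min, in the presence of a further agent that is not named here; on this read-out higher numbers stand for weaker inhibition and lower numbers for stronger inhibition. Compound 1 `CCCCS(=O)(=O)c1sc2nc(-c3nccs3)cc(-c3cnc(C)n3C)c2c1N` gives 32 nM. Compound 2 `Nc1c([S+]([O-])CCCF)sc2nc(-c3cccs3)cc(-c3ccccc3)c12` gives 6.1 nM, the lower of the two numbers, and its gap to compound 1 lies beyond the scatter. Compound 3 `CCC[S+]([O-])c1sc2nc(-c3cccs3)cc(-c3ccccc3)c2c1N` has not been measured. It differs from compound 2 by hydrogen in place of fluoro on a saturated chain carbon, three bonds along the chain from a sulfur. Going by the values given here, no measured pair shows this change, so nothing here fixes its size or direction; the change removes little, and no step beyond the scatter is expected in this assay. The step expected for compound 3 is a 1.3-fold higher number from compound 2 to compound 3 (0.12 log units; within the scatter). Compound 3 is therefore estimated at 8 nM, with a range from 3 nM to 20 nM.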

Compound 3, half-maximal inhibitory concentration: 2.1 nM
Beside the measured number, compound 3's estimate is 3.8-fold (0.58 log units) above it; the whole stated range lies above it.
By their numbers in this assay, from the lowest: compound 3; then compound 2; then compound 1.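

In this assay, going by these compounds alone, hydrogen in place of fluoro on a saturated chain carbon, three bonds along the chain from a sulfur, gives a 2.9-fold lower number from compound 2 to compound 3 (0.46 log units; beyond the scatter) and is the first direct reading of this change. At this place the fluoro is not required for a low number, and the plain propyl chain ranks ahead of 3-fluoropropyl. Nothing available explains the step.

On these data alone, whether an amine or a carboxylic acid at this place would keep the number low remains open. So does whether the same step would appear with other groups on the shared core.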